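Hydroxyethyl to Hydroxypropyl: Compound 2 to Compound 3

This account rests on a few compounds, and the source may have more. Where it says the series, first, only, none or still open, it means among the compounds named here.

Compound 2 `N=c1oc2ccc(Br)cc2cc1C(=O)NCCO` stands lowest of the two measured compounds in an assay on HeLa cells for displacement of a labelled ligand from adenosine receptor A3 (Homo sapiens), read by scintillation counting, with a stated time of 180 min, tested at 10 uM (on this read-out lower numbers stand for less inhibition and higher numbers for more inhibition at the one concentration tested (going by the name of the read-out)), where compound 2 gives 0%, while compound 1 `O=C(NC1CCCC1)c1cc2ccccc2oc1=O` gives 20%, a gap beyond the usual scatter. Compound 3 `N=c1oc2ccc(Br)cc2cc1C(=O)NCCCO` differs from compound 2 by hydroxymethyl in place of hydroxy on a saturated chain carbon, two bonds along the chain from an amide-type nitrogen. Among the compounds with values here, no step between measured compounds is available to set the size of such a change. The step expected from this change is a number 5 percentage points higher from compound 2 to compound 3 (within the scatter), none beyond the scatter. Compound 3 is therefore estimated at 5%, within a range from 0% to 20%.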

Compound 3, a percentage reported as inhibition, at one concentration (the size of the read-out at that concentration, not a potency): 17%
Estimate against measurement, compound 3: 12 percentage points below; measured number inside the range.
By their numbers in this assay, from the lowest: compound 2; then compounds 3 and 1 (each within the scatter of the next).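

In this assay, within the data shown here, hydroxymethyl in place of hydroxy on a saturated chain carbon, two bonds along the chain from an amide-type nitrogen, gives a number 17 percentage points higher from compound 2 to compound 3 (beyond the scatter) and is the first step read at this position. The number therefore responds to the change from 2-hydroxyethyl to 3-hydroxypropyl on this core. Nothing available accounts for the step.

As far as these compounds go, whether a longer chain would move the number further remains open, as does whether an amine or a carboxylic acid could stand in place of the hydroxy. One step also cannot show whether the change would read alike on another core.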